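Swapping Methyl for Isopropyl on Compound 2

The source may hold more compounds than are shown below. What is called first, only, known or untested is meant among the compounds shown, and "the series" means these compounds.

Among the measured compounds shown here, in a functional assay on U-937 cells (Homo sapiens) for cytotoxicity, read by MTT assay, with a stated time of 24 h (on this read-out higher numbers stand for weaker inhibition and lower numbers for stronger inhibition), compound 2 (`Cc1nc2nc(-c3ccccc3)cc(C(F)(F)F)c2c(=O)n1Cc1cn(CCC(F)(F)C(F)(F)C(F)(F)C(F)(F)C(F)(F)C(F)(F)C(F)(F)C(F)(F)F)nn1`) gives 124 ug/mL, the only exact number in this small set. Compound 1 (`Cc1nc2nc(-c3ccccc3)cc(C(F)(F)F)c2c(=O)n1Cc1cn(CCC(F)(F)C(F)(F)C(F)(F)C(F)(F)C(F)(F)C(F)(F)F)nn1`) shows only a limit, > 200 ug/mL. Compound 3 (`Cc1nc2nc(-c3ccccc3)cc(C(F)(F)F)c2c(=O)n1Cc1cn(-c2ccccc2)nn1`) likewise shows only a limit, > 200 ug/mL. Compound 4 (`CC(C)c1nc2nc(-c3ccccc3)cc(C(F)(F)F)c2c(=O)n1Cc1cn(CCC(F)(F)C(F)(F)C(F)(F)C(F)(F)C(F)(F)C(F)(F)C(F)(F)C(F)(F)F)nn1`) changes compound 2 at one place: isopropyl in place of methyl on an aromatic carbon. For the measured compounds named here, the one measured step, an at least 1.6-fold lower number from compound 1 to compound 2 (0.20 log units; that floor lies within the scatter), lies on the fluorinated chain rather than at this carbon, and its floor stays within the scatter, so it gives no ground for expecting a real shift here. The expected step is a 1.0-fold lower number from compound 2 to compound 4 (0.01 log units; within the scatter), none beyond the scatter. For compound 4 the estimated value is 120 ug/mL, with an expected range from 60 ug/mL to 200 ug/mL.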

Compound 4, half-maximal inhibitory concentration: 8.35 ug/mL
Compound 4: the middle estimate sits 14-fold (1.16 log units) above what was measured, and the stated range ends above it.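

The carbon between two ring nitrogen atoms turns out to be sensitive, since a small addition there, isopropyl in place of methyl, gives a 15-fold lower number from compound 2 to compound 4 (1.17 log units; beyond the scatter). On this read-out, a lower number means stronger cytotoxicity towards these cells. The earlier compounds all carry methyl at this carbon, so they could not show this, and two of them give only a limit rather than a number: the limit of > 200 ug/mL in this assay, at which 2 of the 4 values shown sit.

The compounds shown leave open how an ethyl, a tert-butyl or an amine would read at this carbon. They also leave open whether isopropyl would give a similar step on the shorter fluorinated chain of compound 1.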